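The compounds below may be only part of what the source reports. "The series", "measured", "known", "first", "only" and "open" are said of these compounds alone.

Measured so far in a functional assay on HL-60 cells (Homo sapiens) for inhibition; on this read-out higher numbers stand for weaker inhibition of growth and lower numbers for stronger inhibition of growth
Compound 1 `NS(=O)(=O)c1ccc(/C=C/c2ccc(O)c(O)c2)cc1` gives 16300 nM
Compound 2 `COc1cccc(/C=C/c2ccc(S(N)(=O)=O)cc2)c1` gives 10400 nM

Compound 1 has only compound 2 to be compared with, and the two values lie within the usual scatter of each other, so they set no order between the two compounds. The next compound to be measured is compound 3 `NS(=O)(=O)c1ccc(/C=C/c2ccc(O)cc2)cc1`, which keeps the core of compound 1 with one structural change: hydrogen in place of hydroxy on an aromatic carbon. In words, hydrogen stands in place of hydroxy on an aromatic carbon, ortho to a hydroxy group and meta to a large group. Among the compounds with values here, no measured pair isolates this change, so the data give no direct guide to it. Compound 1 at 16300 nM and compound 2 at 10400 nM differ in structure yet stay within the scatter, and so no step beyond the scatter is expected in this assay, in either direction. The estimated step is a 1.4-fold lower number from compound 1 to compound 3 (0.13 log units; within the scatter). Compound 3 is expected at 12000 nM, with an estimated range from 4000 nM to 35000 nM.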

Compound 3, concentration for 50% growth inhibition: 4350 nM
The estimate for compound 3 lay 2.8-fold (0.44 log units) above the measured number; measured number inside the range.
By their numbers in this assay, from the lowest: compound 3; then compounds 2 and 1 (each within the scatter of the next).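

In this assay, the hydroxy group that stands ortho to a hydroxy group and meta to a large group proves not to be neutral: replacing it with hydrogen gives a 3.7-fold lower number from compound 1 to compound 3 (0.57 log units; beyond the scatter), a modest step but one beyond the scatter. The earlier compounds shown here could not show this, since no measured pair isolated any single change, and the two values they gave set no order. In this one pair, the compound with hydrogen at this place inhibits growth more strongly than the compound with hydroxy, so the second hydroxy group on the ring does not add to inhibition here. No measurement bears on why the step occurs, and the data offer no explanation for it.

On these data alone, what remains open is whether the step follows from the loss of hydroxy alone or whether other groups at this place, such as an amine, a fluorine atom or a carboxylic acid, would give numbers nearer to compound 3 or to compound 1. It is also open what the remaining hydroxy group contributes, as the compounds shown include no pair that isolates it.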